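Hydroxyphenyl for Chlorophenyl on the Ring Amine's Side Chain

The compounds below may be only part of what the source reports. "The series", "measured", "known", "first", "only" and "open" are said of these compounds alone.

Compound 1 `COc1cc(N)c(Cl)cc1NC(=O)C1CCN(Cc2ccccc2Cl)CC1` belongs to a small set of amides built on one shared core and tested in a functional assay on the whole organism for antagonist activity, with Mus musculus as the target; on this read-out higher numbers stand for an effect only at larger amounts of compound and lower numbers for an effect already at smaller amounts. In this assay compound 1 gives only a limit of the assay, > 4 mg/kg, and not a number. Compound 2 `COc1cc(N)c(Cl)cc1NC(=O)C1CCN(Cc2cccc(C#N)c2)CC1` likewise gives a limit in this assay, > 4 mg/kg. Compound 3 `COc1cc(N)c(Cl)cc1NC(=O)C1CCN(Cc2cccc(C)c2)CC1` gives a number in this assay, 2.4 mg/kg. The two limits are the same one, (the limit of > 4 mg/kg in this assay, at which 2 of the 3 values shown sit). The step that the two limits leave unreadable from compound 1 to compound 2 therefore cannot be read. The step of an at least 1.6-fold lower number from compound 1 to compound 3 (0.22 log units; that floor lies within the scatter) and the step of an at least 1.6-fold lower number from compound 2 to compound 3 (0.22 log units; that floor lies within the scatter) both point downward, but only as floors that stay within the scatter.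

Compound 4 `COc1cc(N)c(Cl)cc1NC(=O)C1CCN(Cc2ccc(O)cc2)CC1` is the new compound. Compared with compound 1 it shows (4-hydroxyphenyl in place of 2-chlorophenyl on a saturated chain carbon bound to an amine nitrogen in a ring). Among the measured compounds shown here, the only measured step at the same place is the one from compound 1 to compound 3, and it gives no more than a floor within the scatter. For the measured compounds named here, no measured compound carries a hydroxyl on that ring, so no direction beyond the scatter can be expected for this assay. Compound 4 is therefore estimated to give about 4 mg/kg, within a range from 1.5 mg/kg to 12 mg/kg. This estimate means an expected step of a number no higher from compound 1 to compound 4 (the limit leaves the size open).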

Compound 4, dose for half-maximal effect: > 8 mg/kg
Compound 4 ended at the assay's limit; the forecaster's own chance of this, stated with the estimate: 50%; middle value at least 2.0-fold (0.30 log units) away from the limit.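

In this assay, among the compounds shown here, 4-hydroxyphenyl gives the first step at this position that stands clear of the scatter: an at least 3.3-fold higher number from compound 3 to compound 4 (0.52 log units; beyond the scatter). The group on the saturated chain carbon bound to an amine nitrogen in a ring therefore does shape the read-out, and going from 3-methylphenyl to 4-hydroxyphenyl moves it towards an effect only at larger amounts of compound. Compound 4 itself gives only a limit of the assay, and the steps to it from compound 1 and from compound 2 cannot be read: the limit of > 8 mg/kg in this assay, at which 1 of the 4 values shown sits.

In the one readable step, the kind of group and its place on the aromatic ring change together, and the compounds shown do not separate the two. A 4-methylphenyl or a 3-hydroxyphenyl on the same carbon would pull these two changes apart, and a 4-methoxyphenyl would test whether the hydroxyl hydrogen itself matters or only the oxygen.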